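Swapping the hydroxypyridine of compound 2 for a fluorophenyl

The compounds below may be only part of what the source reports. "The series", "measured", "known", "first", "only" and "open" are said of these compounds alone.

Compound 2 `Cc1cccc(NC(=O)CN2CCC(c3ccc(O)cn3)CC2)c1` stands highest of the two measured compounds in a functional assay on HEK293 cells for agonist activity at D(4) dopamine receptor (Homo sapiens), read by FLIPR (a higher number here means a larger maximal response, a lower number a smaller maximal response), where compound 2 gives 83%. Going by the values given here, compound 1 `Cc1cccc(NC(=O)CN2CCC(c3cccc(F)c3)CC2)c1` gives 40%, and the step of a number 43 percentage points higher from compound 1 to compound 2 (beyond the scatter) is the only measured change that bears on the new structure. Compound 3 `Cc1cccc(NC(=O)CN2CCC(c3ccccc3F)CC2)c1` differs from compound 2 as follows: 2-fluorophenyl in place of 5-hydroxypyridin-2-yl on a saturated ring carbon. Since this change removes the very group whose arrival brought the large rise from compound 1, a drop of similar size is expected, roughly a number 38 percentage points lower from compound 2 to compound 3 (beyond the scatter). Compound 3 is therefore estimated at 45%, with a range of 25% to 70%.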

Compound 3, largest response reached (reported as efficacy), in percent of the reference or control that the assay uses: 57%
Beside the measured number, compound 3's estimate is 12 percentage points below it, within the range that was stated.
By their numbers in this assay, from the lowest: compound 1; then compound 3; then compound 2.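

In this assay, replacing the 5-hydroxypyridin-2-yl group with 2-fluorophenyl gives a number 26 percentage points lower from compound 2 to compound 3 (beyond the scatter), so only part of the response is lost. The two fluorophenyl compounds also differ: 2-fluorophenyl in place of 3-fluorophenyl gives a number 17 percentage points higher from compound 1 to compound 3 (beyond the scatter), which shows that the fluorine's place on the phenyl ring matters here as well. Nothing available explains either step.

On these data alone, it remains open whether the hydroxyl or the ring nitrogen of compound 2 accounts for its higher response. Whether an amine in place of that hydroxyl would hold the response is also unknown.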